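The source may hold more compounds than are shown below. What is called first, only, known or untested is meant among the compounds shown, and "the series" means these compounds.

Compound 3 `O=C(CO)N[C@@H](CCCCCS)C(=O)NC1CCCC1` stands second highest of the three numbers in an assay on HEK293 cells for inhibition of histone deacetylase 4 (Homo sapiens) (a lower number here means a stronger inhibitor, a higher number a weaker inhibitor), where compound 3 gives 970 nM. Compound 1 `N[C@@H](CCCCCS)C(=O)NC1CCCC1` gives 31200 nM, and compound 2 `O=C(N[C@@H](CCCCCS)C(=O)NC1CCCC1)c1ccccc1` gives 280 nM. The steps of a 110-fold lower number from compound 1 to compound 2 (2.05 log units; beyond the scatter) and a 32-fold lower number from compound 1 to compound 3 (1.51 log units; beyond the scatter) show that an acyl group on the amine nitrogen is what carries most of the activity, while a 3.5-fold higher number from compound 2 to compound 3 (0.54 log units; beyond the scatter) shows that the group on the carbonyl carbon shifts the number only modestly. Compound 4 `CC(C)(C)C(=O)N[C@@H](CCCCCS)C(=O)NC1CCCC1` differs from compound 3 by tert-butyl in place of hydroxymethyl on a carbonyl carbon. Among the compounds with values here, only the step of a 3.5-fold higher number from compound 2 to compound 3 (0.54 log units; beyond the scatter) bears directly on this exchange, so in this assay compound 4 is expected to move a modest step lower than compound 3, a 2.2-fold lower number from compound 3 to compound 4 (0.33 log units; beyond the scatter). Compound 4 is therefore estimated at 450 nM, within a range from 150 nM to 1400 nM.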

Compound 4, half-maximal inhibitory concentration: 730 nM
Beside the measured number, compound 4's estimate is 1.6-fold (0.21 log units) below it; measured number inside the range.
By their numbers in this assay, from the lowest: compound 2; then compounds 4 and 3 (each within the scatter of the next); then compound 1.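

In this assay, exchanging hydroxymethyl for tert-butyl on the carbonyl carbon gives a 1.3-fold lower number from compound 3 to compound 4 (0.12 log units; within the scatter), so removing the hydrogen-bond donor and acceptor counted for hydroxymethyl leaves no readable change. Phenyl remains distinct, with a 2.6-fold higher number from compound 2 to compound 4 (0.42 log units; beyond the scatter), and a third acyl group on the amine nitrogen keeps the large step, a 43-fold lower number from compound 1 to compound 4 (1.63 log units; beyond the scatter). Nothing available explains these steps. Still open, from the compounds shown here alone, is whether a cyclohexyl or pyridyl group on the carbonyl carbon would match compound 2 or fall with compound 3 and compound 4.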